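This account rests on a few compounds, and the source may have more. Where it says the series, first, only, none or still open, it means among the compounds named here.

Measured in a functional assay on HeLa cells (Homo sapiens) for antiproliferative activity, read by MTT assay, with a stated time of 72 h; on this read-out lower numbers stand for stronger inhibition and higher numbers for weaker inhibition:
- Compound 1 `C=CC(=O)Nc1cccc(Oc2nc(Nc3ccn(C)n3)nc3c2CSCC3)c1` gives 25800 nM
- Compound 2 `CCC/C=C/C(=O)Nc1cccc(Oc2nc(Nc3ccn(C)n3)nc3c2CSCC3)c1` gives 17000 nM
- Compound 3 `C=CC(=O)Nc1cccc(Oc2nc(Nc3cccc(OC)c3)nc3c2CSCC3)c1` gives 28900 nM

Compound 3 does not stand apart on these numbers. Its reading (28900 nM) lies within the scatter of the other two, so the three cannot be ranked. Compound 4 `COc1cccc(Nc2nc3c(c(Oc4cccc(NC(=O)/C=C/C(C)C)c4)n2)CSCC3)c1` differs from compound 3 at a single place (3-methylbut-1-en-1-yl in place of vinyl on a carbonyl carbon), with 3-methylbut-1-en-1-yl in place of vinyl on a carbonyl carbon.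

The closest measured step (a 1.5-fold lower number from compound 1 to compound 2 (0.18 log units; within the scatter)) made a similar exchange at that place, with pent-1-en-1-yl in place of vinyl, and it stayed within the scatter. The other measured step (a 1.1-fold higher number from compound 1 to compound 3 (0.05 log units; within the scatter)) exchanged the group that compound 3 and compound 4 share. It was also within the scatter, so it gives no reason to expect the vinyl exchange to behave differently here.

In this assay, no shift beyond the scatter is therefore expected, though a slightly lower number is possible. The expected step is small (a 1.4-fold lower number from compound 3 to compound 4 (0.16 log units; within the scatter)). For compound 4 the estimated value is 20000 nM (range 10000 nM to 40000 nM).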

Compound 4, half-maximal inhibitory concentration: > 50000 nM
Compound 4 ended at the assay's limit (the forecaster's own chance of this, stated with the estimate: 5%); middle value at least 2.5-fold (0.39 log units) from the limit.
By their numbers in this assay, from the lowest: compounds 2, 1 and 3 (each within the scatter of the next). At a limit, above all of these: compound 4.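

In this assay, compound 4 gives no number, only a limit of the assay: the limit of > 50000 nM in this assay, at which 1 of the 4 values shown sits.

The change of vinyl to 3-methylbut-1-en-1-yl on this carbonyl carbon is read as an at least 1.7-fold higher number from compound 3 to compound 4 (0.23 log units; that floor lies within the scatter), so only a floor for its size is known, and that floor alone does not show a shift beyond the scatter. The earlier exchange at this place, a 1.5-fold lower number from compound 1 to compound 2 (0.18 log units; within the scatter), ended on a measured number, whereas this one takes the reading out of the range the assay reports, which shows that a larger group here can leave the series without a measurable value.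

On these data alone, the true size of the step therefore stays open. Also open, as far as these compounds go, are whether 3-methylbut-1-en-1-yl would read the same with 1-methyl-1H-pyrazol-3-yl on the nitrogen, and how a chain ending in an amine or a carboxylic acid would read on this carbonyl carbon.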